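Swapping the 3-methylbenzyl arm of compound 1 for 2-fluorophenyl

The source may hold more compounds than are shown below. What is called first, only, known or untested is meant among the compounds shown, and "the series" means these compounds.

compound 1 `CCCn1c(=O)[nH]c2nc(-c3ccc(S(=O)(=O)N4CCN(Cc5cccc(C)c5)CC4)cc3)[nH]c2c1=O` — 795 nM
compound 2 `CCCn1c(=O)[nH]c2nc(-c3ccc(S(=O)(=O)N4CCN(C)CC4)cc3)[nH]c2c1=O` — 334 nM
compound 3 `CCCn1c(=O)[nH]c2nc(-c3ccc(S(=O)(=O)N4CCN(Cc5cccc(Br)c5)CC4)cc3)[nH]c2c1=O` — 928 nM

Three compounds on a shared core were measured in an assay on CHO cells for displacement of a labelled ligand from adenosine receptor A1 (Homo sapiens), read by scintillation counting, with a stated time of 90 min, in the presence of a further agent that is not named here; a higher number here means a weaker inhibitor, a lower number a stronger inhibitor. Compound 1 gives the second highest of the three numbers; compound 3 lies within the scatter of it, while compound 2 gives a lower number. The step of a 2.4-fold lower number from compound 1 to compound 2 (0.38 log units; beyond the scatter) and the reverse-sense step a 2.8-fold higher number from compound 2 to compound 3 (0.44 log units; beyond the scatter) show that removing or adding an aryl-bearing arm on the ring amine nitrogen moves the number only modestly, and a 1.2-fold higher number from compound 1 to compound 3 (0.07 log units; within the scatter) shows that exchanging a substituent on that aryl ring changes nothing beyond the scatter. Compound 4 `CCCn1c(=O)[nH]c2nc(-c3ccc(S(=O)(=O)N4CCN(c5ccccc5F)CC4)cc3)[nH]c2c1=O` carries the change (2-fluorophenyl in place of 3-methylbenzyl on an amine nitrogen in a ring). Both compound 1 and compound 4 keep an aryl group on that nitrogen, so the step of a 1.1-fold lower number from compound 1 to compound 4 (0.06 log units; within the scatter) is expected to stay within the scatter. Compound 4 is therefore estimated at 700 nM, between 350 nM and 1400 nM.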

Compound 4, inhibition constant: > 1000 nM
Compound 4 ended at the assay's limit; the forecaster's own chance of this, stated with the estimate: 5%; middle value at least 1.4-fold (0.15 log units) from the limit.
By their numbers in this assay, from the lowest: compound 2; then compounds 1 and 3 (each within the scatter of the next). At a limit, above all of these: compound 4.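

Compound 4 stands at a limit rather than a number: the limit of > 1000 nM in this assay, at which 1 of the 4 values shown sits. Even so, the step of an at least 2.9-fold higher number from compound 2 to compound 4 (0.47 log units; beyond the scatter) is at least modest for 2-fluorophenyl in place of methyl on an amine nitrogen in a ring, so this arm, like the 3-methylbenzyl and 3-bromobenzyl arms, sits apart from the methyl of compound 2. On these data alone, the steps of an at least 1.2-fold higher number from compound 1 to compound 4 (0.09 log units; that floor lies within the scatter) and an at least 1.0-fold higher number from compound 3 to compound 4 (0.03 log units; that floor lies within the scatter) cannot be read, as each floor lies within the scatter, so it stays unknown whether 2-fluorophenyl differs from those benzyl arms. The compounds shown leave open what an unsubstituted phenyl, a carboxylic acid on the aryl ring, or a longer chain on that nitrogen would give.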